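Removing the aromatic methyl: a small step into the unknown

The compounds below may be only part of what the source reports. "The series", "measured", "known", "first", "only" and "open" are said of these compounds alone.

Compounds measured so far:
Compound 1, `Cc1ccc(N2CCN/C2=N\N)cc1`: 9%
Compound 2, `Cc1cccc(N2CCn3c2n[nH]c(=O)c3=O)c1C`: 18%

In an ADME assay on Vero cells (Chlorocebus sabaeus) for cytotoxicity, with a stated time of 72 h, tested at 50 ug/mL (a higher number here means a stronger effect of the compound at the concentration tested, a lower number a weaker effect), compound 1 gives 9%. In this assay compound 2 gives 18%. Compound 1 stands at the lower end of these two numbers, yet the distance to compound 2 lies within the usual scatter, so the two cannot be told apart on this evidence.

The next compound is compound 3, `N/N=C1\NCCN1c1ccccc1`, which has not yet been measured in this assay. It differs from compound 1 in one place: hydrogen in place of methyl on an aromatic carbon. The change is the smallest the structure allows, a single carbon removed from an aromatic carbon of the six-membered ring. Among the measured compounds shown here, no pair of measured compounds shows what such a change does here, so the step is expected to be none beyond the scatter, with the result staying near that of compound 1.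

For compound 3 the value in this assay is estimated at 10%, within a range from 0% to 25%, which means an expected step of a number 1 percentage points higher from compound 1 to compound 3 (within the scatter).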

Compound 3, a percentage reported as inhibition, at one concentration (the size of the read-out at that concentration, not a potency): 0%
Beside the measured number, compound 3's estimate is 10 percentage points above it; measured number inside the range.
By their numbers in this assay, from the lowest: compounds 3, 1 and 2 (each within the scatter of the next, the first and the last beyond it).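

Among the compounds shown here, the pair gives the first reading of this position: with hydrogen in place of methyl on an aromatic carbon, para to a group of 7 heavy atoms, this assay shows a number 9 percentage points lower from compound 1 to compound 3 (within the scatter). Compound 1 and compound 3 therefore cannot be told apart, and the methyl at this place is not shown to matter for the read-out. Nothing measured here speaks to why the step has this size.

On these data alone, only methyl and hydrogen are compared at this place, in a single pair, so what an amine, a methoxy group or a carboxylic acid would do on the same carbon stays open. Also open, as far as these compounds go, is whether a methyl on another carbon of the ring would give the same result.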